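Amide-nitrogen aryl variation in the catechol ether amide series

The compounds below may be only part of what the source reports. "The series", "measured", "known", "first", "only" and "open" are said of these compounds alone.

Measured so far:
- compound 1, `COc1ccc(C(=O)Nc2c(F)cccc2F)cc1OC1CCCC1`; in an assay on isolated protein for inhibition of phosphodiesterase 4A (Sus scrofa) (on this read-out lower numbers stand for stronger inhibition and higher numbers for weaker inhibition), compound 1 gives 70 nM.
- compound 2, `COc1ccc(C(=O)Nc2ccccn2)cc1OC1CCCC1`; in this assay compound 2 gives 1000 nM.
- compound 3, `COc1ccc(C(=O)Nc2c(Br)cncc2Br)cc1OC1CCCC1`; in this assay compound 3 gives 7 nM.

Compound 3 stands lowest of the three numbers. It is separated from compound 1 by a 10-fold lower number from compound 1 to compound 3 (1.00 log units; beyond the scatter) and from compound 2 by a 140-fold lower number from compound 2 to compound 3 (2.15 log units; beyond the scatter); both steps lie beyond the scatter, so compound 3 is the strongest inhibitor of the set so far.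

Compound 4, `COc1ccc(C(=O)Nc2c(C)nsc2Br)cc1OC1CCCC1`, differs from compound 3 at the amide nitrogen only: 5-bromo-3-methyl-1,2-thiazol-4-yl in place of 3,5-dibromopyridin-4-yl on an amide-type nitrogen. Among the measured compounds shown here, the steps that bear on this change are the two that end at compound 3, since each also exchanges the aryl group on the same nitrogen: a 10-fold lower number from compound 1 to compound 3 (1.00 log units; beyond the scatter) and a 140-fold lower number from compound 2 to compound 3 (2.15 log units; beyond the scatter). For the measured compounds named here, compound 4 keeps a bromine and an aromatic ring on that nitrogen, but the ring type and the second substituent change, and no measured step isolates either of these. The expected outcome in this assay is therefore a modest rise, smaller than either measured step. For compound 4 the estimate is 20 nM, with a range of 6 nM to 70 nM. The expected step is a 2.9-fold higher number from compound 3 to compound 4 (0.46 log units; beyond the scatter).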

Compound 4, half-maximal inhibitory concentration: 500 nM
Compound 4: the middle estimate sits 25-fold (1.40 log units) below what was measured, and the stated range ends below it.
By their numbers in this assay, from the lowest: compound 3; then compound 1; then compounds 4 and 2 (each within the scatter of the next).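

In this assay, a bromine and an aromatic ring on the amide-type nitrogen prove insufficient to hold the low number of compound 3: moving to 5-bromo-3-methyl-1,2-thiazol-4-yl gives a 71-fold higher number from compound 3 to compound 4 (1.85 log units; beyond the scatter). The same group also falls short of 2,6-difluorophenyl, with a 7.1-fold higher number from compound 1 to compound 4 (0.85 log units; beyond the scatter), while a 2.0-fold lower number from compound 2 to compound 4 (0.30 log units; within the scatter) places it within the scatter of pyridin-2-yl, so a bromine-bearing ring here need not read differently from a ring without halogen. The activity at this position therefore depends on more than the presence of bromine, and no available evidence accounts for the size of the step from the six-membered to the five-membered ring.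

Ring type and second substituent change together in compound 4, so the compounds shown cannot say which of the two carries the step. A 3,5-dichloropyridin-4-yl group would test how far the second halogen can vary on the six-membered ring, and a 5-bromo-1,2-thiazol-4-yl group without the methyl would test the five-membered ring apart from that substituent.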